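From Ester to Benzyl Amide on a Shared Core

This account rests on a few compounds, and the source may have more. Where it says the series, first, only, none or still open, it means among the compounds named here.

Measured compounds in a functional assay on the whole organism for inhibition, with Hamster (Cricetinae) as the target, at a dose of 10 mg/kg by the intravenous route; on this read-out higher numbers stand for a stronger effect at the one dose given and lower numbers for a weaker effect:
compound 1 `COC(=O)C(=O)[C@@H](NC(=O)[C@@H]1CCCN1C(=O)[C@@H](NC(=O)Cn1ccc(=O)n(CC(=O)O)c1=O)C(C)C)C(C)C` gives 94%
compound 2 `COC(=O)C(=O)[C@@H](NC(=O)[C@@H]1CCCN1C(=O)[C@@H](NC(=O)CN1CCN(CC(=O)O)C(=O)C1=O)C(C)C)C(C)C` gives 94%

For the measured compounds named here, compound 2 stands level with compound 1, the only measured step being no change at the digits printed from compound 1 to compound 2 (within the scatter), which concerns a different part of the core. Compound 3 `CC(C)[C@H](NC(=O)[C@@H]1CCCN1C(=O)[C@@H](NC(=O)CN1CCN(CC(=O)O)C(=O)C1=O)C(C)C)C(=O)C(=O)NCc1ccccc1` differs from compound 2 by benzylamino in place of methoxy on a carbonyl carbon. No measured step touches this position, so nothing shown speaks for or against a shift in this assay; compound 2 already sits high on this read-out. Compound 3 is therefore expected to stay close, with a step of a number 6 percentage points lower from compound 2 to compound 3 (within the scatter). The estimate for compound 3 in this assay is 88%, ranging from 65% to 98%.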

Compound 3, a percentage reported as inhibition, in the whole organism at one dose (the size of the read-out at that dose, not a potency): 89%
Estimate against measurement, compound 3: 1 percentage points below; the range from low to high includes it.
By their numbers in this assay, from the lowest: compounds 3, 1 and 2 (each within the scatter of the next).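

Placing benzylamino in place of methoxy on this carbonyl carbon gives a number 5 percentage points lower from compound 2 to compound 3 (within the scatter) in this assay. The earlier compounds shown here left this position untested; here, the larger group with its aromatic ring and hydrogen-bond donor is accommodated without a step beyond the scatter at this one dose. No measurement shown offers an explanation for this result. The compounds shown leave open how a carboxylic acid or a phenethylamino group on this carbonyl carbon would read in this assay. They also leave open whether benzylamino gives the same outcome on the core of compound 1.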